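Swapping a difluorophenyl amide for a small polar ring

A few compounds are considered here, and "the series" means these few. Any claim that something is new, unique, unknown or untested is made for them only; others in the source may bear on it.

Compound 3 `COc1ccc2nc(C)cc(OCC(=O)Nc3cc(F)cc(F)c3)c2c1` gives 13000 nM in a physicochemical assay for solubility, in phosphate buffer, measured as kinetic solubility, with a stated time of 1 h, at pH 7.4 (a lower number here means a less soluble compound, a higher number a more soluble compound), the second highest of the three numbers: it lies within the scatter of compound 2 `Cc1cc(C)cc(NC(=O)COc2cc(C)nc3ccc(C(F)(F)F)cc23)c1`, which gives 10000 nM, and clearly below compound 1 `Cc1cc(C)cc(NC(=O)COc2cc(C)nc3ccc(C)cc23)c1`, which gives 83000 nM. Among the measured compounds shown here, the only single-point step among the measured compounds is an 8.3-fold lower number from compound 1 to compound 2 (0.92 log units; beyond the scatter), and it concerns the aromatic part of the core, not the amide side. Compound 4 `COc1ccc2nc(C)cc(OCC(=O)NC3CONC3=O)c2c1` differs from compound 3 by a group of 6 heavy atoms (3 carbon, 1 nitrogen, 2 oxygen; one five-membered non-aromatic ring with 2 hetero atoms) in place of a group of 8 heavy atoms (6 carbon, 2 fluorine; one six-membered aromatic ring of carbon only), on an amide-type nitrogen. For the measured compounds named here, no measured step bears on this change, so the expectation rests on the change itself: a higher number is expected, with the step of a 4.6-fold higher number from compound 3 to compound 4 (0.66 log units; beyond the scatter). Compound 4 is therefore estimated at 60000 nM, within a range from 20000 nM to 200000 nM.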

Compound 4, solubility: >= 166000 nM
Compound 4 gave a limit, no number; the forecaster's own chance of this, stated with the estimate: 15%; at least 2.7-fold (0.44 log units) between middle value and limit.
By their numbers in this assay, from the lowest: compounds 2 and 3 (each within the scatter of the next); then compound 1. At a limit, above all of these: compound 4.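

Among the compounds shown here, replacing the 3,5-difluorophenyl with the five-membered non-aromatic ring on the amide-type nitrogen gives an at least 12-fold higher number from compound 3 to compound 4 (1.10 log units; beyond the scatter) and is the only measured step on the amide side, whereas the earlier step concerned the aromatic part of the core. This shows that the group on this nitrogen can shift the read-out by a large margin. For compound 4 the result in this assay is a limit and not a number: the limit of >= 166000 nM in this assay, at which 1 of the 4 values shown sits.

Going by these compounds, how far compound 4 lies past this limit remains open. So does whether an open-chain group, such as a hydroxyethyl chain or a carboxylic acid, on the same nitrogen would give a similar step.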